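Compound 3 to compound 4: an aryl swap

The source may report more compounds than this note shows. Statements on the series, on what has been measured and on what is new or still open speak of the compounds shown alone.

Measured in a functional assay on MDA-MB-231 cells (Homo sapiens) for inhibition, read by MTT assay, with a stated time of 48 h (a lower number here means a stronger inhibitor of growth, a higher number a weaker inhibitor of growth), so far:
- compound 1 `S=C(Nc1ccccc1)Nc1ccc2ncnc(Nc3cccc(Br)c3)c2c1` gives 10000 nM
- compound 2 `S=C(Nc1ccc(Cl)cc1)Nc1ccc2ncnc(Nc3cccc(Br)c3)c2c1` gives 8200 nM
- compound 3 `FC(F)(F)c1cccc(NC(=S)Nc2ccc3ncnc(Nc4cccc(Br)c4)c3c2)c1` gives 1400 nM

Compound 3 holds the lowest number of the three, and its steps to both others lie beyond the scatter. Compound 4 `S=C(Nc1ccc(Br)cc1)Nc1ccc2ncnc(Nc3cccc(Br)c3)c2c1` follows with 4-bromophenyl in place of 3-(trifluoromethyl)phenyl on an amide-type nitrogen. The closest measured precedent is a 5.9-fold lower number from compound 2 to compound 3 (0.77 log units; beyond the scatter), which the new change roughly reverses. Also relevant are a 1.2-fold lower number from compound 1 to compound 2 (0.09 log units; within the scatter) and a 7.1-fold lower number from compound 1 to compound 3 (0.85 log units; beyond the scatter). A return towards the level of compound 2 is therefore expected, a clear rise in this assay. The expected step is a 5.4-fold higher number from compound 3 to compound 4 (0.73 log units; beyond the scatter) in this series. For compound 4 the estimated value is 7500 nM with an expected range from 3000 nM to 15000 nM in this assay.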

Compound 4, concentration for 50% growth inhibition: > 30000 nM
Compound 4 gave a limit, no number; the forecaster's own chance of this, stated with the estimate: 10%; middle value at least 4.0-fold (0.60 log units) away from the limit.
By their numbers in this assay, from the lowest: compound 3; then compounds 2 and 1 (each within the scatter of the next). At a limit, above all of these: compound 4.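

Compound 4 gives only a limit, not a number, in this assay: the limit of > 30000 nM in this assay, at which 1 of the 4 values shown sits. Changing the halogen on the aryl group at this nitrogen has a measurable effect, with an at least 3.6-fold higher number from compound 2 to compound 4 (0.56 log units; beyond the scatter), and the bromo compound also separates from the unsubstituted one, with an at least 3.0-fold higher number from compound 1 to compound 4 (0.47 log units; beyond the scatter), although chloro in place of hydrogen stayed within the scatter. With an at least 21-fold higher number from compound 3 to compound 4 (1.33 log units; beyond the scatter), the aryl group on this nitrogen spans a wider range than compounds 1 to 3 showed.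

As far as these compounds go, the true value of compound 4 remains open. So does whether a methoxy, an amine or a carboxylic acid on this aryl group would match compound 3.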